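This account rests on a few compounds, and the source may have more. Where it says the series, first, only, none or still open, it means among the compounds named here.

Compound 1 `Cn1c(=N)sc2cc(OC(F)(F)F)ccc21`: 5 mg/kg
Compound 2 `CCCCn1c(=N)sc2cc(OC(F)(F)F)ccc21`: 10 mg/kg
Compound 3 `CCN(CC)C(=O)Cn1c(=N)sc2cc(OC(F)(F)F)ccc21`: 9 mg/kg

These three compounds have been tested in a functional assay on the whole organism with Rattus norvegicus as the target; on this read-out lower numbers stand for an effect already at smaller amounts and higher numbers for an effect only at larger amounts of compound. Compound 3 holds the second highest of the three numbers; its nearest neighbour is compound 2 and its furthest is compound 1, and both of those gaps lie within the scatter, so none of the three can be ranked against another on this read-out. Compound 4 `C[S+]([O-])CCn1c(=N)sc2cc(OC(F)(F)F)ccc21` has not yet been measured. It differs from compound 3 in one place: a group of 4 heavy atoms (2 carbon, 1 oxygen, 1 sulfur; no ring) in place of a group of 7 heavy atoms (5 carbon, 1 nitrogen, 1 oxygen; no ring), on a saturated chain carbon bound to an aromatic nitrogen. Two measured steps end at compound 3 and bear on this exchange, since they alter the same position: a 1.8-fold higher number from compound 1 to compound 3 (0.26 log units; within the scatter) and a 1.1-fold lower number from compound 2 to compound 3 (0.05 log units; within the scatter). The step of a 2.0-fold higher number from compound 1 to compound 2 (0.30 log units; within the scatter) changes that position as well. Every exchange so far on the saturated chain carbon bound to an aromatic nitrogen has left the number within the scatter, so no step beyond the scatter is expected for compound 4 in this assay in either direction. Compound 4 is therefore estimated at 9 mg/kg, with a range from 4 mg/kg to 20 mg/kg. This estimate means an expected step of no change at the digits printed from compound 3 to compound 4 (within the scatter).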

Compound 4, dose for half-maximal effect: 1.1 mg/kg
Compound 4: the middle estimate sits 8.2-fold (0.91 log units) above what was measured; measured number outside the range, below it.
By their numbers in this assay, from the lowest: compound 4; then compounds 1, 3 and 2 (each within the scatter of the next).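

In this assay, among these compounds, the exchange on the saturated chain carbon bound to an aromatic nitrogen that leads to compound 4 is the first at this position to go beyond the scatter (an 8.2-fold lower number from compound 3 to compound 4 (0.91 log units; beyond the scatter)). The number also falls beyond the scatter against the other two compounds (a 9.1-fold lower number from compound 2 to compound 4 (0.96 log units; beyond the scatter); a 4.5-fold lower number from compound 1 to compound 4 (0.66 log units; beyond the scatter)), so compound 4 stands lowest of the four and the position is shown not to be indifferent to what it carries. Heavy-atom count does not order this result, as the entering group of 4 heavy atoms gives a lower number than both the hydrogen atom of compound 1 and the diethylcarbamoyl group of compound 3.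

The compounds shown leave open whether a thioether, a sulfone or a longer chain ending in the same sulfur group would keep this lower number. No measurement shown explains the fall.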